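The source may report more compounds than this note shows. Statements on the series, on what has been measured and on what is new or still open speak of the compounds shown alone.

Measured compounds:
- compound 1, `COc1cc(C)cc(-c2c(-c3ccnc(-c4ccc(C(C)=O)cc4)c3)cnn2CC#N)c1`: 25%
- compound 2, `Cc1cc(O)cc(-c2nn(CC#N)cc2-c2ccnc(-c3ccc(Oc4ccccc4)cc3)c2)c1`: -37%
- compound 3, `COc1cc(C)cc(-c2nn(CC#N)cc2-c2ccnc(-c3ccc(N(C)C)cc3)c2)c1`: 14%

All three were tested in a functional assay on A549 cells (Homo sapiens) for cytotoxicity, read by sulforhodamine B assay, with a stated time of 48 h, tested at 1 uM; a lower number here means a stronger effect, a higher number a weaker effect of the compound at the concentration tested. On these numbers compound 3 gives 14% and stands second highest of the three. Its nearest neighbour is compound 1, whose value is higher by a margin beyond the usual scatter, so compound 1 shows the weaker effect of the two. The furthest is compound 2, whose value lies far lower, again beyond the scatter, so compound 2 shows the strongest effect of the three. Going by the values given here, compound 2 differs from the other two in more than one place, so no single step among the measured compounds isolates one change.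

The next compound, compound 4, `Cc1cc(O)cc(-c2nn(CC#N)cc2-c2ccnc(-c3ccc(N(C)C)cc3)c2)c1`, differs from compound 3 in one place only: hydrogen in place of methyl on an oxygen on an aromatic ring. Among the compounds with values here, compound 2 is the only measured compound that also carries the hydroxy, but it differs at a second place too, so the effect of this change alone has not been measured.

In this assay the step of a number 14 percentage points lower from compound 3 to compound 4 (beyond the scatter) is expected to move toward a lower number by an amount just beyond the scatter, with wide uncertainty. Compound 4 is therefore estimated to give 0%, in a range from -35% to 30%.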

Compound 4, a percentage reported as activity, at one concentration (the size of the read-out at that concentration, not a potency): 23%
Estimate against measurement, compound 4: 23 percentage points below; the measured number falls inside the stated range.
By their numbers in this assay, from the lowest: compound 2; then compounds 3, 4 and 1 (each within the scatter of the next, the first and the last beyond it).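

In this assay, methoxy to hydroxy on the 3-methoxy-5-methylphenyl group gives a number 9 percentage points higher from compound 3 to compound 4 (within the scatter), so with dimethylamino on the far aromatic ring, removing the methyl from this oxygen produces no change that can be told apart from repeat-to-repeat variation. With the hydroxy held constant, the change from phenoxy to dimethylamino gives a number 60 percentage points higher from compound 2 to compound 4 (beyond the scatter), showing that in this pair the outcome depends strongly on that other aromatic substituent and that hydroxy alone does not fix the read-out at the level seen for compound 2 . No supporting data bear on why either step has this size.

The compounds shown leave open whether methoxy to hydroxy would also make so little difference with phenoxy in place of dimethylamino, since compound 2 has no methoxy partner here. They also leave open how a longer ether such as ethoxy, or an amino group in place of the hydroxy, would read on the same aromatic ring.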